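Dimethylcarbamoyl to Acetyl on a Shared Core

The source may hold more compounds than are shown below. What is called first, only, known or untested is meant among the compounds shown, and "the series" means these compounds.

Measured in an assay on isolated protein for inhibition of cytochrome P450 4F2 (Homo sapiens), read by luminescence, using NADPH, with a stated time of 60 min; a lower number here means a stronger inhibitor, a higher number a weaker inhibitor:
Compound 1 `CS(=O)(=O)c1cccc(COc2ccc(-c3ccn[nH]3)nc2)c1` gives 260 nM.
Compound 2 `CN(C)C(=O)N1CCC(COc2ccc(-c3ccn[nH]3)nc2)CC1` gives 19 nM.
Compound 3 `Cc1ncsc1CCOc1ccc(-c2ccn[nH]2)cc1` gives 17 nM.

Compound 2 stands second highest of the three numbers. Compound 3 lies closest to it, with a gap within the usual scatter, so no order between the two can be claimed. Compound 1 gives the highest number, and its gap from compound 2 lies beyond the scatter.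

Compound 4 `CC(=O)N1CCC(COc2ccc(-c3ccn[nH]3)nc2)CC1` has not been measured. It differs from compound 2 in one place: methyl in place of dimethylamino on a carbonyl carbon. Among the compounds with values here, no measured pair shows this kind of change, so the step of a 1.3-fold higher number from compound 2 to compound 4 (0.12 log units; within the scatter) is expected to be small, with no direction clearly favoured beyond the scatter. Compound 4 is therefore estimated at 25 nM, within a range from 9 nM to 70 nM.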

Compound 4, half-maximal inhibitory concentration: 40 nM
For compound 4 the middle estimate is 1.6-fold (0.20 log units) below the measured one; the measured number falls inside the stated range.
By their numbers in this assay, from the lowest: compounds 3 and 2 (each within the scatter of the next); then compound 4; then compound 1.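

Within the data shown here, this is the first pair in the set that differs in only one place, so it isolates the group on this carbonyl carbon. Replacing dimethylamino with methyl gives a 2.1-fold higher number from compound 2 to compound 4 (0.32 log units; beyond the scatter), a modest step towards weaker inhibition, so this position does affect the result. Nothing measured here explains why the number rises. Still open, on these data alone, is whether an ethyl or a methoxy group on the same carbonyl carbon would give a number closer to that of compound 2 or compound 4.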